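The source may hold more compounds than are shown below. What is called first, only, known or untested is meant among the compounds shown, and "the series" means these compounds.

Compound 1 `Cc1cn([C@@H]2O[C@H](CO)[C@@H](CN)[C@H]2O)c(=O)[nH]c1=O` was tested in a functional assay on CCRF-CEM cells (Homo sapiens) for antiproliferative activity, with a stated time of 72 h; on this read-out higher numbers stand for an effect only at larger amounts of compound and lower numbers for an effect already at smaller amounts. Compound 1 gives > 100 uM, which is a limit of the assay rather than a number. Compound 2 `Cc1cn([C@@H]2O[C@H](CO)[C@@H](CO)[C@H]2O)c(=O)[nH]c1=O` differs from compound 1 by hydroxy in place of amino on a saturated chain carbon bound to a saturated ring carbon. Compound 2 likewise gives only a limit, > 100 uM. Accordingly, a step that the two limits leave unreadable from compound 1 to compound 2. Compound 3 `Cc1cn([C@H]2C[C@H](CN)[C@@H](CO)O2)c(=O)[nH]c1=O` carries a different core, differing from compound 1 by hydrogen in place of hydroxy on a saturated ring carbon. Compound 3 too gives a limit, > 100 uM. Thus a step that the two limits leave unreadable from compound 1 to compound 3. Compound 4 `Cc1cn([C@H]2C[C@H](CO)[C@@H](CO)O2)c(=O)[nH]c1=O` is not yet measured; it differs from compound 3 by hydroxy in place of amino on a saturated chain carbon bound to a saturated ring carbon, the same change as that made from compound 1 to compound 2. Compound 4 is expected to show a step that the limit leaves unreadable from compound 3 to compound 4 in this assay because compound 1, compound 2 and compound 3 all sit at the limit of > 100 uM in this assay, at which 3 of the 3 values shown sit. For compound 4 the estimated value is therefore 150 uM.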

Compound 4, concentration for half-maximal effect: 1 uM
Compound 4: the middle estimate sits 150-fold (2.18 log units) above what was measured, and the stated range ends above it.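

In this assay, on the core of compound 3, aminomethyl to hydroxymethyl gives an at least 100-fold lower number from compound 3 to compound 4 (2.00 log units; beyond the scatter), and hydrogen in place of hydroxy on a saturated ring carbon gives an at least 100-fold lower number from compound 2 to compound 4 (2.00 log units; beyond the scatter). The same aminomethyl to hydroxymethyl change on the core of compound 1 cannot be read, because compound 1 and compound 2 both stand at a limit of the assay: the limit of > 100 uM in this assay, at which 3 of the 4 values shown sit. So the large drop is seen on one core only, and how far the change carries to the core of compound 1 is not shown.

From the compounds shown here alone, it stays open whether hydroxymethyl in particular is needed, or whether a carboxylic acid or a longer chain bearing hydroxy would serve at this place. Going by these compounds, how a fluorine in place of the hydrogen on that saturated ring carbon would behave also stays open.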